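Anilide series: cytotoxicity and the trimethoxyphenyl step

The source may hold more compounds than are shown below. What is called first, only, known or untested is meant among the compounds shown, and "the series" means these compounds.

Compound 1 `COc1ccc(NC(=O)c2csc(-c3cn(Cc4ccc(Cl)cc4)c4ccccc34)n2)cc1` gives > 100000 nM in an ADME assay on HEK-293T cells (Homo sapiens) for cytotoxicity, read by MTT assay, with a stated time of 48 h, in the absence of a further agent (a lower number here means a stronger inhibitor, a higher number a weaker inhibitor), a limit.
Compound 2 `O=C(Nc1ccccc1)c1csc(-c2cn(Cc3ccc(Cl)cc3)c3ccccc23)n1` gives > 100000 nM in this assay, a limit.

Compound 2 sits at the limit of > 100000 nM in this assay, at which 2 of the 2 values shown sit. Within the data shown here, the step that the two limits leave unreadable from compound 1 to compound 2 is thus not readable, and no measured step gives a direction for the series. Compound 3 `COc1cc(NC(=O)c2csc(-c3cn(Cc4ccc(Cl)cc4)c4ccccc34)n2)cc(OC)c1OC` differs from compound 2 by 3,4,5-trimethoxyphenyl in place of phenyl on an amide-type nitrogen. With both measured values at the limit, the step to compound 3 is expected to stay within the unreadable range, as a number no higher from compound 2 to compound 3 (the limit leaves the size open). Compound 3 is therefore estimated at 100000 nM, in a range from 30000 nM to 300000 nM, most probably reported again only as a limit.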

Compound 3, half-maximal inhibitory concentration: 58700 nM
Compound 3: the middle estimate sits 1.7-fold (0.23 log units) above what was measured; low and high end bracket the measured number.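

Among these compounds, compound 3 is the first anilide here to give a number rather than a limit in this assay, with 3,4,5-trimethoxyphenyl on the amide-type nitrogen: the limit of > 100000 nM in this assay, at which 2 of the 3 values shown sit. Replacing phenyl gives an at least 1.7-fold lower number from compound 2 to compound 3 (0.23 log units; that floor lies within the scatter), and replacing 4-methoxyphenyl gives an at least 1.7-fold lower number from compound 1 to compound 3 (0.23 log units; that floor lies within the scatter). Both are floors within the scatter, so they show only that this position can bring a readable value, not how large the change is.

Still open, going by these compounds, is how a 3,5-dimethoxyphenyl or 4-aminophenyl group on the same nitrogen would read in this assay. Whether all three methoxy groups are needed for a readable value also remains unsettled.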